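A Benzyl Swap on the Piperazine Nitrogen

The source may hold more compounds than are shown below. What is called first, only, known or untested is meant among the compounds shown, and "the series" means these compounds.

Of the compounds shown here, three have so far been tested in a functional assay on HeLa cells (Homo sapiens) for antiproliferative activity, read by CCK-8 assay, with a stated time of 72 h, tested at 2 uM; on this read-out lower numbers stand for a weaker effect and higher numbers for a stronger effect at the one concentration tested. Compound 1, with structure `Nc1ccccc1NC(=O)c1ccc(CSC(=S)N2CCN(c3ccc(Cl)cc3)CC2)cc1`, gives 51.2%. Compound 3, `Nc1ccccc1NC(=O)c1ccc(CSC(=S)N2CCCC2)cc1`, gives 51.3%, a number that lies within the usual scatter of compound 1, so the two cannot be told apart. Compound 2, `Nc1ccccc1NC(=O)c1ccc(CSC(=S)N(Cc2ccccc2)Cc2ccccc2)cc1`, gives 1%, far below both of them and beyond the scatter. Compound 1 thus stands second highest of the three numbers, with compound 3 at its side and compound 2 well beneath.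

Compound 4, `Nc1ccccc1NC(=O)c1ccc(CSC(=S)N2CCN(Cc3ccccc3)CC2)cc1`, has not yet been measured. It differs from compound 1 in one place: benzyl in place of 4-chlorophenyl on an amine nitrogen in a ring. Within the data shown here, no measured pair shows this exact change. Compound 2 carries two benzyl groups on an open nitrogen and gives 1%, whereas compound 1 and compound 3 each keep a ring on that nitrogen and give the higher numbers. Compound 4 keeps the ring of compound 1 and brings in one benzyl group. A moderate downward step is expected, a number 11.2 percentage points lower from compound 1 to compound 4 (beyond the scatter), perhaps no larger than the scatter. Compound 4 is therefore estimated at 40%, with a range from 10% to 60%.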

Compound 4, a percentage reported as inhibition, at one concentration (the size of the read-out at that concentration, not a potency): 20.6%
For compound 4 the middle estimate is 19.4 percentage points above the measured one; low and high end bracket the measured number.
By their numbers in this assay, from the lowest: compound 2; then compound 4; then compounds 1 and 3 (each within the scatter of the next).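

In this assay, benzyl in place of 4-chlorophenyl on the amine nitrogen in the ring brings a number 30.6 percentage points lower from compound 1 to compound 4 (beyond the scatter), which shows that the read-out depends strongly on which group sits at this position, even with the ring kept. The size of this step stands out, since the two groups match in heavy atoms, each has one six-membered aromatic ring of carbon only, and neither has hydrogen-bond donors, hydrogen-bond acceptors or a net charge. No measurement here explains why the two groups differ so much.

The change removes a chlorine and adds a carbon in one step, so the compounds shown leave open which of the two matters. A plain phenyl group or a 4-chlorobenzyl group on this nitrogen would separate them.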